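This account rests on a few compounds, and the source may have more. Where it says the series, first, only, none or still open, it means among the compounds named here.

Working notes on the sulfamate series, antiproliferative read-out.

Compound 1 `CO[C@H](C(=O)NS(=O)(=O)OC[C@H]1O[C@@H](n2cnc3c(N)nc(Cl)nc32)[C@H](O)[C@@H]1O)[C@H](OC)C(C)C` is assessed in a functional assay on SK-HEP1 cells (Homo sapiens) for antiproliferative activity, read by sulforhodamine B assay, with a stated time of 72 h; a higher number here means a weaker inhibitor, a lower number a stronger inhibitor. In this assay compound 1 gives only a limit, > 20000 nM, and no number. Among the measured compounds shown here, the second measured member, compound 2 `Nc1ncnc2c1ncn2[C@@H]1O[C@H](COS(=O)(=O)NC(=O)[C@@H](O)[C@H](O)C2CC2)[C@@H](O)[C@@H]1O`, gives 7260 nM in this assay; it differs from compound 1 in more than one place, so no single step between the two can be drawn, and their values are taken only as they stand.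

Compound 3 `CC(C)C[C@H](Cl)C(=O)NS(=O)(=O)OC[C@H]1O[C@@H](n2cnc3c(N)nc(Cl)nc32)[C@H](O)[C@@H]1O` is the next member to be tested. Relative to compound 1 the change is a group of 6 heavy atoms (5 carbon, 1 chlorine; no ring) in place of a group of 9 heavy atoms (7 carbon, 2 oxygen; no ring), on a carbonyl carbon, with the new group sitting on the carbonyl carbon whose other neighbour is the amide-type nitrogen. For the measured compounds named here, no measured pair isolates a change at this position, and the only anchor, compound 1, is a limit (the limit of > 20000 nM in this assay, at which 1 of the 2 values shown sits), so the direction of the step is open. The expected step in this assay from compound 1 to compound 3 is an at least 1.3-fold lower number from compound 1 to compound 3 (0.12 log units; that floor lies within the scatter), with a fair chance that the result is again reported as a limit. Compound 3 is estimated at 15000 nM, between 4000 nM and 60000 nM.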

Compound 3, half-maximal inhibitory concentration: 5870 nM
For compound 3 the middle estimate is 2.6-fold (0.41 log units) above the measured one; the range from low to high includes it.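

In this assay there is an at least 3.4-fold lower number from compound 1 to compound 3 (0.53 log units; beyond the scatter) when the group of 6 heavy atoms (5 carbon, 1 chlorine; no ring) replaces the group of 9 heavy atoms (7 carbon, 2 oxygen; no ring), on a carbonyl carbon whose other neighbour is the amide-type nitrogen. This is the only readable step shown at this position, and it shows that a change here alone, with the rest of compound 1 kept, is enough to move the antiproliferative read-out beyond the scatter. Compound 1 stands only at a limit, so the step is a floor and its full size stays unknown: the limit of > 20000 nM in this assay, at which 1 of the 3 values shown sits.

The change removes the two oxygens and brings in the chlorine in a single step, and the compounds shown do not separate these two parts of it. Also open, on these data alone, is how an amine in place of the chlorine, or a longer chain on the same carbonyl carbon, would read in this assay against compound 3.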